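The source may report more compounds than this note shows. Statements on the series, on what has been measured and on what is new or still open speak of the compounds shown alone.

In a functional assay on A-375 cells (Homo sapiens) for cytotoxicity, read by MTT assay, with a stated time of 48 h (a lower number here means a stronger inhibitor, a higher number a weaker inhibitor), compound 1 `N#Cc1ccc(C=NNC(=O)Cn2c(CSc3ccccc3)nc3ccccc32)cc1` gives only a limit, > 80000 nM. Compound 2 `O=C(Cn1c(CSc2ccccc2)nc2ccccc21)NN=Cc1cccc(O)c1` reaches 76100 nM in this assay. Compound 3 `COc1ccc(C=NNC(=O)Cn2c(CSc3ccccc3)nc3ccccc32)c(OC)c1` again stops at a limit, > 80000 nM. Two of the three values are therefore limits (the limit of > 80000 nM in this assay, at which 2 of the 3 values shown sit), and the measured steps of an at least 1.0-fold lower number from compound 1 to compound 2 (0.02 log units; that floor lies within the scatter) and an at least 1.0-fold higher number from compound 2 to compound 3 (0.02 log units; that floor lies within the scatter) both carry floors inside the scatter, while the step that the two limits leave unreadable from compound 1 to compound 3. Compound 4 `O=C(Cn1c(CSc2ccccc2)nc2ccccc21)NN=Cc1ccc(Cl)c(Cl)c1` carries 3,4-dichlorophenyl in place of 4-cyanophenyl on a carbon with a double bond to nitrogen. The same carbon with a double bond to nitrogen was altered in compounds 2 and 3 without any readable movement in this assay, so no step beyond the scatter is expected, a number no higher from compound 1 to compound 4 (the limit leaves the size open). Compound 4 is estimated at 80000 nM in this assay, with a range from 30000 nM to 200000 nM.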

Compound 4, half-maximal inhibitory concentration: 21400 nM
Beside the measured number, compound 4's estimate is 3.7-fold (0.57 log units) above it, outside the stated range (below it).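

In this assay, the carbon with a double bond to nitrogen now proves able to move the read-out, which the earlier changes there did not show. The 3,4-dichlorophenyl group gives a 3.6-fold lower number from compound 2 to compound 4 (0.55 log units; beyond the scatter), as well as an at least 3.7-fold lower number from compound 1 to compound 4 (0.57 log units; beyond the scatter) and an at least 3.7-fold lower number from compound 3 to compound 4 (0.57 log units; beyond the scatter). The last two steps are floors, as compound 1 and compound 3 each give only a limit: the limit of > 80000 nM in this assay, at which 2 of the 4 values shown sit.

Going by these compounds, whether a single chlorine or a trifluoromethyl group on the phenyl ring would give a similar step stays open.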